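Series notes: difluorophenoxy in place of oxanylamino

The source may hold more compounds than are shown below. What is called first, only, known or untested is meant among the compounds shown, and "the series" means these compounds.

Values in a functional assay on OVCAR-3 cells (Homo sapiens) for antiproliferative activity; on this read-out higher numbers stand for weaker inhibition of growth and lower numbers for stronger inhibition of growth:
- compound 1 `Cc1cc(-c2cnn3c(NCC4CCOCC4)nc(NC4CCOCC4)nc23)ccc1C(=O)NC1CC1`: 780 nM
- compound 3 `O=C(NC1CC1)c1ccc(-c2cnn3c(NCC4CCOCC4)nc(NC4CCCC4)nc23)cc1`: 1700 nM
- compound 2 `CN(c1nc(NCC2CCOCC2)n2ncc(-c3ccc(C(=O)NC4CC4)c(F)c3)c2n1)C1CCCCC1`: "not determined" (no result reported)

Compound 1 holds the lowest of the two numbers in this assay; compound 3 stands higher, and the gap between the two lies beyond the usual scatter. Compound 2 carries no number in this assay and adds nothing to the comparison. Compounds 1 and 3 differ in more than one place, so no single step can be read from them.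

Compound 4 `Cc1cc(-c2cnn3c(NCC4CCOCC4)nc(Oc4cccc(F)c4F)nc23)ccc1C(=O)NC1CC1` is the next entry: 2,3-difluorophenoxy in place of (oxan-4-yl)amino on an aromatic carbon. Within the data shown here, no measured pair shows this kind of exchange, a hydrogen-bond donor leaving and an aromatic ether entering on the shared core, so the expectation rests on nothing closer than compound 1 itself and is correspondingly wide. The step from compound 1 to compound 4 in this assay is expected to be a moderate rise, a 2.6-fold higher number from compound 1 to compound 4 (0.41 log units; beyond the scatter), beyond the scatter but not large. Compound 4 is accordingly estimated at 2000 nM in this assay, with a range from 500 nM to 8000 nM.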

Compound 4, concentration for 50% growth inhibition: 37 nM
The estimate for compound 4 lay 54-fold (1.73 log units) above the measured number; the measured number lies below the stated range.
By their numbers in this assay, from the lowest: compound 4; then compound 1; then compound 3.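

Working at the site opposite the ring nitrogen, between two ring nitrogen atoms, 2,3-difluorophenoxy in place of (oxan-4-yl)amino in this assay gives a 21-fold lower number from compound 1 to compound 4 (1.32 log units; beyond the scatter) and is a large step, the first single-place change readable in this series. The hydrogen-bond donor of (oxan-4-yl)amino is therefore not required at this position for growth inhibition in compound 4, and an aromatic ether is accepted there on the shared core. No measurement at hand accounts for the size of this step.

The exchange alters the ring, the linking atom and the fluorine atoms together, so the share of each in the step stays unresolved. Unsubstituted phenoxy and phenylamino at this position would separate the fluorine atoms and the ether oxygen from the aromatic ring.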